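Cyclopentyl in place of sec-butyl on a shared core

A few compounds are considered here, and "the series" means these few. Any claim that something is new, unique, unknown or untested is made for them only; others in the source may bear on it.

Compound 1, `CC(C)CCn1nc(C2CCC2)c(O)c(C2=NS(=O)(=O)c3cc(NS(C)(=O)=O)ccc3N2)c1=O`: > 33000 nM
Compound 2, `C/C(=C\c1nn(CCC(C)C)c(=O)c(C2=NS(=O)(=O)c3cc(NS(C)(=O)=O)ccc3N2)c1O)C(F)(F)F`: > 33000 nM
Compound 3, `CCC(C)CCn1nc(-c2cccs2)c(O)c(C2=NS(=O)(=O)c3cc(NS(C)(=O)=O)ccc3N2)c1=O`: > 1000 nM

In an ADME assay on Huh-7 cells (Homo sapiens) for cytotoxicity, with a stated time of 72 h (on this read-out lower numbers stand for higher toxicity in this test and higher numbers for lower toxicity in this test), compound 1 gives > 33000 nM, which is a limit and not a number. Compound 2 gives > 33000 nM, likewise a limit. The step that the two limits leave unreadable from compound 1 to compound 2 is therefore not readable. Compound 3 gives > 1000 nM, again a limit, so compound 3 stands only at a threshold and its place among the three cannot be ranked; the two thresholds are the limit of > 1000 nM in this assay, at which 1 of the 3 values shown sits, and (the limit of > 33000 nM in this assay, at which 2 of the 3 values shown sit).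

The piece follows compound 3 to compound 4, `CS(=O)(=O)Nc1ccc2c(c1)S(=O)(=O)N=C(c1c(O)c(-c3cccs3)nn(CCC3CCCC3)c1=O)N2`, with the change (cyclopentyl in place of sec-butyl on a saturated chain carbon, two bonds along the chain from an aromatic nitrogen). Within the data shown here, no measured pair shares this change, and the one measured step, from compound 1 to compound 2, gives no size. There is thus no evidence for a step in either direction beyond the scatter, and compound 4 is expected to sit near compound 3, most likely again as a limit; the expected step is a step that the limit leaves unreadable from compound 3 to compound 4. Compound 4 is estimated at 33000 nM, with a range from 5000 nM to 100000 nM.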

Compound 4, half-maximal cytotoxic concentration: > 1000 nM
Compound 4: only a limit was reported; the forecaster's own chance of this, stated with the estimate: 80%; the middle value lies beyond the limit too.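

In this assay compound 3 gives > 1000 nM, which is a limit. Compound 4 gives > 1000 nM, likewise a limit. Among these compounds, no step from one to the other can therefore be read. The compounds shown leave open where compound 3 and compound 4 actually lie in this assay, and whether cyclopentyl in place of sec-butyl makes any difference there.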